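Series notes: 4-chlorophenyl to 2-chlorophenyl

This account rests on a few compounds, and the source may have more. Where it says the series, first, only, none or still open, it means among the compounds named here.

In a functional assay on MCF7 cells (Homo sapiens) for antiproliferative activity, read by MTT assay, with a stated time of 72 h (a lower number here means a stronger inhibitor, a higher number a weaker inhibitor), compound 1 `Nc1nc(N)c2cc(CSC(=S)N3CCN(c4ccccc4)CC3)ccc2n1` gives 2950 nM and compound 2 `Nc1nc(N)c2cc(CSC(=S)N3CCN(c4ccc(Cl)cc4)CC3)ccc2n1` gives 4880 nM, so compound 2 stands level with compound 1 within the scatter. Compound 3 `Nc1nc(N)c2cc(CSC(=S)N3CCN(c4ccccc4Cl)CC3)ccc2n1` carries 2-chlorophenyl in place of 4-chlorophenyl on an amine nitrogen in a ring. Among the compounds with values here, the only measured step that bears on this is a 1.7-fold higher number from compound 1 to compound 2 (0.22 log units; within the scatter), with chloro in place of hydrogen on an aromatic carbon. Within the data shown here, no measured step moves the chloro group, so nothing beyond the scatter is expected in this assay. The expected change is a 1.2-fold lower number from compound 2 to compound 3 (0.09 log units; within the scatter). Compound 3 is estimated at 4000 nM, with an expected range of 1500 nM to 10000 nM.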

Compound 3, half-maximal inhibitory concentration: 3190 nM
Compound 3: the middle estimate sits 1.3-fold (0.10 log units) above what was measured; the range from low to high includes it.
By their numbers in this assay, from the lowest: compounds 1, 3 and 2 (each within the scatter of the next).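

In this assay, moving the chloro group gives a 1.5-fold lower number from compound 2 to compound 3 (0.18 log units; within the scatter), so the compounds do not separate 2-chlorophenyl from 4-chlorophenyl on this ring nitrogen. The chloro group in its new place also stays level with plain phenyl, with a 1.1-fold higher number from compound 1 to compound 3 (0.03 log units; within the scatter), so neither chlorophenyl is separated from the unsubstituted ring. No measurement is available that would explain this result. Going by these compounds, whether a methoxy group or a carboxylic acid on this phenyl ring would move the number beyond the scatter remains open.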